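Replacing the methoxyphenyl arm of compound 1 with a phenethyl chain

A few compounds are considered here, and "the series" means these few. Any claim that something is new, unique, unknown or untested is made for them only; others in the source may bear on it.

Measured compounds:
compound 1 `COc1ccc(Cn2ccc3nc(-c4ccccc4)nc-3c2)cc1` gives > 100000 nM in an ADME assay on MDBK cells (Bos taurus) for cytotoxicity; on this read-out lower numbers stand for higher toxicity in this test and higher numbers for lower toxicity in this test
compound 2 `CC(C)(C)c1ccc(Cn2ccc3nc(-c4ccccc4)nc-3c2)cc1` gives 22000 nM in this assay
compound 3 `FC(F)(F)Oc1ccc(Cn2ccc3nc(-c4ccccc4)nc-3c2)cc1` gives 66000 nM in this assay

The reading for compound 1 is a limit of the assay, not a number, so compound 1 stands at the least toxic end of the three shown, marked by the limit of > 100000 nM in this assay, at which 1 of the 3 values shown sits. The unmeasured compound 4 `c1ccc(CCCn2ccc3nc(-c4ccccc4)nc-3c2)cc1` differs from compound 1 by phenethyl in place of 4-methoxyphenyl on a saturated chain carbon bound to an aromatic nitrogen. Within the data shown here, two measured steps bear on such a change at the same place. Swapping the methoxy for tert-butyl gave an at least 4.5-fold lower number from compound 1 to compound 2 (0.65 log units; beyond the scatter), a move toward higher toxicity, while the change to trifluoromethoxy gave an at least 1.5-fold lower number from compound 1 to compound 3 (0.18 log units; that floor lies within the scatter). Between the two, a 3.0-fold higher number from compound 2 to compound 3 (0.48 log units; beyond the scatter). Removing the methoxy-bearing ring and putting in a plain phenyl on a longer chain resembles the first step more than the second, so a modest drop in the number is expected, with the limit still possible. Compound 4 is therefore estimated at 50000 nM, between 15000 nM and 200000 nM, which would mean an at least 2.0-fold lower number from compound 1 to compound 4 (0.30 log units; that floor lies within the scatter).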

Compound 4, half-maximal cytotoxic concentration: > 100000 nM
Compound 4: a limit, no number; the forecaster's own chance of this, stated with the estimate: 40%; middle value at least 2.0-fold (0.30 log units) away from the limit.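

In this assay compound 1 and compound 4 each give a limit of the assay rather than a number, so the step between them cannot be read: the limit of > 100000 nM in this assay, at which 2 of the 4 values shown sit. The compounds shown leave open whether phenethyl in place of 4-methoxyphenyl changes this read-out at all.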